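The compounds below may be only part of what the source reports. "The series", "measured", "known", "first", "only" and "open" are said of these compounds alone.

Working notes on the series, all values from an assay on cells for inhibition of cytochrome P450 11B2, mitochondrial (Homo sapiens), read by HTRF; a higher number here means a weaker inhibitor, a lower number a stronger inhibitor:

- compound 1, `Cc1cccnc1C(=O)NCc1cncc(N2C(=O)c3ccc(Cl)cc3C2(C)C)c1`, gives 9 nM
- compound 2, `CCS(=O)(=O)N[C@@H]1CCCc2c1cncc2N1Cc2cc(Cl)ccc2C1=O`, gives 40 nM
- compound 3, `N#Cc1ccc2c(c1)CN(c1cccnc1)C2=O`, gives 232 nM

Compound 2 stands second highest of the three numbers. Its nearest neighbour is compound 1, whose number is lower by a margin beyond the usual scatter; compound 3 lies furthest away, with a higher number, again beyond the scatter. Going by the values given here, no pair among the three differs in only one place, so no measured step is available as a guide.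

Compound 4, `CCC(=O)N[C@@H]1CCCc2c1cncc2N1Cc2cc(Cl)ccc2C1=O`, is derived from compound 2 by the change (propanoyl in place of ethylsulfonyl on an amine nitrogen). The amine nitrogen keeps its saturated ring carbon neighbour; only the acyl partner changes, from a sulfonyl to a carbonyl group. Among the compounds with values here, with no measured step of this kind among the three compounds, the expectation rests on the shared core alone: in this assay compound 4 is expected to stay close to compound 2, with the step of a 1.1-fold lower number from compound 2 to compound 4 (0.06 log units; within the scatter) most likely within or only just beyond the scatter, in either direction. The estimate for compound 4 is 35 nM, with a range from 12 nM to 110 nM.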

Compound 4, half-maximal inhibitory concentration: 28 nM
For compound 4 the middle estimate is 1.3-fold (0.10 log units) above the measured one; measured number inside the range.
By their numbers in this assay, from the lowest: compound 1; then compounds 4 and 2 (each within the scatter of the next); then compound 3.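

In this assay, the step at this amine nitrogen gives a 1.4-fold lower number from compound 2 to compound 4 (0.15 log units; within the scatter) as propanoyl replaces ethylsulfonyl. Going by these compounds alone, this is the first measured step, and it shows that, on a nitrogen whose other neighbour is a saturated ring carbon, the sulfonyl and carbonyl partners cannot be told apart here, even though propanoyl has one fewer hydrogen-bond acceptor and fewer heavy atoms. No independent measurement is available to explain this match between the two groups.

Still open is how far this tolerance extends: the compounds shown do not tell whether a free amine, a methyl carbamate, a urea or a longer acyl chain on this nitrogen would keep the number in the same range. As far as these compounds go, whether the same exchange behaves alike on another core also remains unknown.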